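The compounds below may be only part of what the source reports. "The series", "measured", "known", "first", "only" and "open" are said of these compounds alone.

Working notes on the series. Among the compounds with values here, compound 2 `COc1ccc(-c2cn(C/C=C3\OC(=O)C(OCc4ccccc4)=C3OCc3ccccc3)nn2)cc1` stands weakest of the three measured so far: in a functional assay on MCF7 cells (Homo sapiens) for antiproliferative activity, read by MTT assay, with a stated time of 72 h (on this read-out higher numbers stand for weaker inhibition and lower numbers for stronger inhibition), compound 2 gives 39100 nM. Compound 3 `O=C1O[C@H]([C@@H](O)Cn2cc(CNS(=O)(=O)c3ccc(Cl)cc3F)nn2)C(OCc2ccccc2)=C1OCc1ccccc1` gives 3390 nM in this assay, the nearest number, and the gap lies beyond the scatter. Compound 1 `CC(C)(C)c1cn(C[C@H](O)[C@H]2OC(=O)C(OCc3ccccc3)=C2OCc2ccccc2)nn1` gives 730 nM in this assay, the furthest number, again beyond the scatter. Both differ from compound 2 in more than one place, so their values only show that the rest of the set sits well below compound 2.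

Compound 4 `O=C1O/C(=C\Cn2cc(-c3ccc(Br)cc3)nn2)C(OCc2ccccc2)=C1OCc1ccccc1` is the next point. It differs from compound 2 by one change, bromo in place of methoxy on an aromatic carbon: the methoxy leaves and a bromo enters, on an aromatic carbon of a six-membered aromatic ring of carbon only, para to a large group, so that 4-methoxyphenyl becomes 4-bromophenyl. Within the data shown here, no measured pair in the set shares this swap, so nothing anchors its size. A small step, within the scatter or slightly toward stronger inhibition, is expected, a 1.6-fold lower number from compound 2 to compound 4 (0.19 log units; within the scatter). Compound 4 is therefore estimated at 25000 nM in this assay, with a range from 8000 nM to 80000 nM.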

Compound 4, half-maximal inhibitory concentration: > 100000 nM
Compound 4: a limit, no number; the forecaster's own chance of this, stated with the estimate: 10%; middle value at least 4.0-fold (0.60 log units) from the limit.
By their numbers in this assay, from the lowest: compound 1; then compound 3; then compound 2. At a limit, above all of these: compound 4.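

Bromo in place of methoxy, on an aromatic carbon para to a large group, is the first single change seen in this series, and it gives an at least 2.5-fold higher number from compound 2 to compound 4 (0.40 log units; beyond the scatter), so this position does not tolerate every substituent equally. In this assay compound 4 gives > 100000 nM, which is a limit of the assay and not a number. The step therefore has a lower bound but no measured size: the limit of > 100000 nM in this assay, at which 1 of the 4 values shown sits.

The pair cannot show whether the shift follows from methoxy leaving or bromo entering, and an amine or a hydroxy group on the same carbon would help to separate the two. As far as these compounds go, whether the same swap carries over to the core of compound 1, with its hydroxy-bearing chain, also remains open.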